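This account rests on a few compounds, and the source may have more. Where it says the series, first, only, none or still open, it means among the compounds named here.

In a functional assay with Mus musculus as the target (a higher number here means a weaker inhibitor, a lower number a stronger inhibitor), compound 1 `CCNC1CCCc2onc(O)c21` gives 391000 nM. Compound 2 `C=CCNC1CCCc2onc(O)c21` returns only a limit, > 1000000 nM. Compound 3 `OCCNC1CCCc2onc(O)c21` also returns only a limit, > 1000000 nM, so it has no numerical place on this scale. The series therefore stands at the limit of > 1000000 nM in this assay, at which 2 of the 3 values shown sit.

Compound 4 `Oc1noc2c1C(N1CCCC1)CCC2` differs from compound 3 at one place: pyrrolidin-1-yl in place of (2-hydroxyethyl)amino on a saturated ring carbon. In short, pyrrolidin-1-yl takes the place of (2-hydroxyethyl)amino on a saturated ring carbon.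

For the measured compounds named here, three measured steps concern this same substituent. Two lie beyond the scatter and are at least modest: an at least 2.5-fold higher number from compound 1 to compound 2 (0.40 log units; beyond the scatter) and an at least 2.5-fold higher number from compound 1 to compound 3 (0.40 log units; beyond the scatter). The third, a step that the two limits leave unreadable from compound 2 to compound 3, cannot be read. None of them involves a ring in the substituent, so they give only weak guidance, and no readable step is expected from compound 3. The expected change is an at least 1.2-fold lower number from compound 3 to compound 4 (0.09 log units; that floor lies within the scatter), and a report of only a limit is quite likely. For compound 4 the estimated value is 800000 nM, with an expected range of 250000 nM to 2500000 nM.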

Compound 4, half-maximal inhibitory concentration: > 1000000 nM
Compound 4: only a limit was reported; the forecaster's own chance of this, stated with the estimate: 60%; middle value at least 1.2-fold (0.09 log units) from the limit.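

In this assay compound 4 returns only a limit, > 1000000 nM. Pyrrolidin-1-yl in place of ethylamino on the saturated ring carbon gives an at least 2.5-fold higher number from compound 1 to compound 4 (0.40 log units; beyond the scatter), so a substituent with a ring and no hydrogen-bond donors moves the same way as the allylamino and (2-hydroxyethyl)amino groups of compound 2 and compound 3. The steps among compound 2, compound 3 and compound 4 cannot be read, and ethylamino remains the only substituent shown with a numerical value on this scale, while the others share one ceiling: the limit of > 1000000 nM in this assay, at which 3 of the 4 values shown sit.

On these data alone, it stays open whether methylamino, a free primary amine or a piperidin-1-yl ring at this carbon would give a numerical value. As far as these compounds go, the order among allylamino, (2-hydroxyethyl)amino and pyrrolidin-1-yl also remains unknown.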